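Aryl ether in place of ethyl on compound 1

A few compounds are considered here, and "the series" means these few. Any claim that something is new, unique, unknown or untested is made for them only; others in the source may bear on it.

Measured compounds:
compound 1 `CCOc1ccc([C@@H]2CC(=O)c3cc(CC=C(C)C)c(OC)cc3O2)cc1`, 57%
compound 2 `COc1ccc([C@@H]2C/C(=N/OCc3cn(-c4cccc(CO)c4)nn3)c3cc(CC=C(C)C)c(OC)cc3O2)cc1`, 42%
compound 3 `COc1cc2c(cc1CC1OC1(C)C)C(=O)C[C@@H](c1ccc(O)cc1)O2`, 98%

In a functional assay on MCF7 cells (Homo sapiens) for inhibition, read by sulforhodamine B assay, with a stated time of 48 h, tested at 50 uM (a lower number here means less inhibition of growth, a higher number more inhibition of growth at the concentration tested), compound 1 gives 57%, the second highest of the three numbers. Compound 2 sits lower, by a gap beyond the scatter, and compound 3 sits higher, also beyond the scatter. Among the measured compounds shown here, no pair of these three differs in a single place, so no step size from one change alone is known within the measured set.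

Compound 4 `COc1cc2c(cc1CC=C(C)C)C(=O)C[C@@H](c1ccc(Oc3ccc(Br)cc3)cc1)O2` is to be measured in this assay. It differs from compound 1 in one place: 4-bromophenyl in place of ethyl on an oxygen on an aromatic ring.

For the measured compounds named here, with no single-change step to lean on, only a modest move is expected. The expected step of a number 5 percentage points higher from compound 1 to compound 4 (within the scatter) is small, in the direction of slightly more inhibition, but not clearly beyond the scatter. Compound 4 is estimated at 62%, with a range from 38% to 86%.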

Compound 4, percent growth inhibition at one concentration: 68%
For compound 4 the middle estimate is 6 percentage points below the measured one; the range from low to high includes it.
By their numbers in this assay, from the lowest: compound 2; then compound 1; then compound 4; then compound 3.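

In this assay, among the compounds shown here, the change from ethoxy to 4-bromophenoxy gives a number 11 percentage points higher from compound 1 to compound 4 (beyond the scatter) and is the first single-place step. The oxygen on the aromatic ring therefore carries 4-bromophenyl, with its seven heavy atoms and six-membered aromatic ring, in place of the two-carbon ethyl without loss of growth inhibition at the concentration tested, and the read-out moves up rather than down. Nothing available bears on why the step has this direction or size.

For the compounds shown here, the single step does not separate the contribution of the aromatic ring from that of the bromine, so unsubstituted phenyl on the same oxygen would be the direct comparison with compound 4. From the compounds shown here alone, a longer chain such as n-butyl on that oxygen, or an amine or carboxylic acid on the added ring, also remains open.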